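This account rests on a few compounds, and the source may have more. Where it says the series, first, only, none or still open, it means among the compounds named here.

Compound 3 `Cc1ccc(-n2nnc3c(C(N)=O)ncn3c2=O)cc1` gives 0.125 h in an ADME assay for pharmacokinetics (a lower number here means that the compound disappears faster, a higher number that the compound lasts longer), the smallest of the three numbers in hand, though the step of a 1.1-fold lower number from compound 1 to compound 3 (0.03 log units; within the scatter) places compound 1 `CCOc1ccc(-n2nnc3c(C(N)=O)ncn3c2=O)cc1` at 0.133 h within the scatter of it. Among the measured compounds shown here, compound 2 `CCCn1nnc2c(C(N)=O)ncn2c1=O`, with 2.58 h in this assay, is the only member that clearly lasts longer. Compound 4 `COc1ccc(-n2nnc3c(C(N)=O)ncn3c2=O)cc1` differs from compound 3 by methoxy in place of methyl on an aromatic carbon. For the measured compounds named here, the one step that bears on this, the exchange of an ethoxy for a methyl from compound 1 to compound 3, stayed within the scatter, so an exchange between methyl and methoxy at the same carbon is expected to bring no step beyond the scatter in this assay either, a 1.0-fold higher number from compound 3 to compound 4 (0.02 log units; within the scatter). Compound 4 is therefore estimated at 0.13 h, with a range from 0.06 h to 0.3 h.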

Compound 4, half-life: 0.142 h
For compound 4 the middle estimate is 1.1-fold (0.04 log units) below the measured one; the measured number falls inside the stated range.
By their numbers in this assay, from the lowest: compounds 3, 1 and 4 (each within the scatter of the next); then compound 2.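

With methoxy in place of methyl on this aromatic carbon, para to a large group, a 1.1-fold higher number from compound 3 to compound 4 (0.06 log units; within the scatter) in this assay. Going from ethoxy to methoxy gives the same reading, a 1.1-fold higher number from compound 1 to compound 4 (0.03 log units; within the scatter), so methyl, methoxy and ethoxy at this place cannot be told apart, and the entry of the oxygen with its hydrogen-bond acceptor brings no step beyond the scatter. Nothing available explains this flat result.

On these data alone, whether an amine, a carboxylic acid or a longer chain at this carbon would move the number beyond the scatter stays open. Also open, as far as these compounds go, is which feature of compound 2, at 2.58 h, could carry over to these compounds.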